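This account rests on a few compounds, and the source may have more. Where it says the series, first, only, none or still open, it means among the compounds named here.

Compound 3 `COc1cc2nccc(Oc3ccc(NC(=O)c4cc(-c5ccc(F)cc5)on4)cc3)c2cc1OC` carries 5-(4-fluorophenyl)-1,2-oxazol-3-yl on the amide carbonyl and in a functional assay on A549 cells (Homo sapiens) for antiproliferative activity, read by MTT assay, with a stated time of 72 h (a lower number here means a stronger inhibitor, a higher number a weaker inhibitor), gives 40400 nM, the highest number among the three measured compounds. The nearest is compound 2 `COc1cc2nccc(Oc3ccc(NC(=O)c4nnc(-c5ccc(F)cc5)o4)cc3)c2cc1OC`, which gives 5140 nM; furthest is compound 1 `COc1cc2c(Oc3ccc(NC(=O)c4nc(-c5ccc(F)cc5)no4)cc3)ccnc2cc1OCCCN1CCC(C)CC1`, which gives 870 nM. Compound 4 `COc1cc2nccc(Oc3ccc(NC(=O)c4nc(-c5ccc(F)cc5)no4)cc3)c2cc1OC` differs from compound 3 in one place: 3-(4-fluorophenyl)-1,2,4-oxadiazol-5-yl in place of 5-(4-fluorophenyl)-1,2-oxazol-3-yl on a carbonyl carbon. Going by the values given here, the one measured step bearing on this is the ring exchange on the same core, a 7.9-fold higher number from compound 2 to compound 3 (0.90 log units; beyond the scatter), where a 1,2-oxazol-3-yl entering for a 1,3,4-oxadiazol-2-yl raised the number. The present change runs the other way, a 1,2,4-oxadiazol-5-yl entering for the 1,2-oxazol-3-yl, so a downward step of comparable size in this assay is expected, a 10-fold lower number from compound 3 to compound 4 (1.00 log units; beyond the scatter). Compound 1 holds the same 3-(4-fluorophenyl)-1,2,4-oxadiazol-5-yl but with a different side chain, and its value of 870 nM cannot be read as a single-place comparison. Compound 4 is therefore estimated at 4000 nM, within a range of 1300 nM to 12000 nM.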

Compound 4, half-maximal inhibitory concentration: 10300 nM
The estimate for compound 4 lay 2.6-fold (0.41 log units) below the measured number; low and high end bracket the measured number.
By their numbers in this assay, from the lowest: compound 1; then compounds 2 and 4 (each within the scatter of the next); then compound 3.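

In this assay, the shared core now carries three different rings on the amide carbonyl. The 3-(4-fluorophenyl)-1,2,4-oxadiazol-5-yl group shows a 3.9-fold lower number from compound 3 to compound 4 (0.59 log units; beyond the scatter) against the 5-(4-fluorophenyl)-1,2-oxazol-3-yl group, but a 2.0-fold higher number from compound 2 to compound 4 (0.30 log units; within the scatter) against the 5-(4-fluorophenyl)-1,3,4-oxadiazol-2-yl group, so the two oxadiazoles are not separated and only the 1,2-oxazol-3-yl ring stands apart. The 2-(4-methylpiperidin-1-yl)ethyl group, replaced by hydrogen, accounts for a 12-fold higher number from compound 1 to compound 4 (1.07 log units; beyond the scatter), a larger step than either ring exchange into the 1,2,4-oxadiazole. No measurement shown explains these differences.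

Still open, on these data alone, is whether the 2-(4-methylpiperidin-1-yl)ethyl effect carries over to the 1,3,4-oxadiazol-2-yl or 1,2-oxazol-3-yl amides. Also open, as far as these compounds go, is how a morpholine or a carboxylic acid at the end of that chain would compare.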